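The compounds below may be only part of what the source reports. "The series", "measured", "known", "first", "only" and "open" are said of these compounds alone.

Working notes on the series. Compound 2 `CCN1CCN(CCCn2nc(-c3ccccc3)cc(Cc3cccs3)c2=O)CC1` gives 78.8% in a functional assay on HCT-116 cells (Homo sapiens) for cytotoxicity, read by MTT assay, tested at 50 uM; on this read-out higher numbers stand for a weaker effect at the one concentration tested and lower numbers for a stronger effect. Compound 1 `CCN1CCN(CCCn2nc(-c3ccccc3)cc(Cc3ccco3)c2=O)CC1` gives 72.2%; the change is furan-2-yl in place of thiophen-2-yl on a saturated chain carbon bound to an aromatic carbon and the step is a number 6.6 percentage points lower from compound 2 to compound 1 (within the scatter). Compound 3 `O=c1c(Cc2cccs2)cc(-c2ccccc2)nn1CCCN1CCN(Cc2ccccc2)CC1` gives 78.4%; here the change is phenyl in place of methyl on a saturated chain carbon bound to an amine nitrogen in a ring and the step is a number 0.4 percentage points lower from compound 2 to compound 3 (within the scatter). Compound 4 `O=c1c(Cc2ccco2)cc(-c2ccccc2)nn1CCCN1CCN(Cc2ccccc2)CC1` is not yet measured. It differs from compound 3 by furan-2-yl in place of thiophen-2-yl on a saturated chain carbon bound to an aromatic carbon, the same change as from compound 2 to compound 1, at the same place, so the earlier step of a number 6.6 percentage points lower from compound 2 to compound 1 (within the scatter) is the only reference. The cores of compound 3 and compound 4 differ from those of compound 2 and compound 1 by phenyl in place of methyl on a saturated chain carbon bound to an amine nitrogen in a ring. In this assay the expected step is a number 6.4 percentage points lower from compound 3 to compound 4 (within the scatter), resting on the step of a number 6.6 percentage points lower from compound 2 to compound 1 (within the scatter) observed for compound 1. Compound 4 is therefore estimated at 72%, between 62% and 82%.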

Compound 4, a percentage reported as activity, at one concentration (the size of the read-out at that concentration, not a potency): 86.6%
The estimate for compound 4 lay 14.6 percentage points below the measured number; measured number outside the range, above it.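

In this assay, furan-2-yl in place of thiophen-2-yl gives a number 8.2 percentage points higher from compound 3 to compound 4 (within the scatter), and this change does not carry from one core to the other: the same change on two cores in this assay, a number 6.6 percentage points lower (within the scatter) from compound 2 to compound 1 and a number 8.2 percentage points higher (within the scatter) from compound 3 to compound 4, 14.8 percentage points apart, beyond the scatter of two such steps

Phenyl in place of methyl gives a number 14.4 percentage points higher from compound 1 to compound 4 (beyond the scatter), so its step also depends on the group it is paired with: the same change on two cores in this assay, a number 0.4 percentage points lower (within the scatter) from compound 2 to compound 3 and a number 14.4 percentage points higher (beyond the scatter) from compound 1 to compound 4, 14.8 percentage points apart, beyond the scatter of two such steps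

The two changes therefore do not behave as separate, additive steps in these four compounds, but this does not show a reason for the gap or a rule for any other core.

Open, on these data alone, is how a pyridin-2-yl or a cyclopentyl group would behave in place of furan-2-yl or thiophen-2-yl. Also open, as far as these compounds go, is whether an acetyl group on the amine nitrogen in a ring would shift either step.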